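This account rests on a few compounds, and the source may have more. Where it says the series, first, only, none or still open, it means among the compounds named here.

In a functional assay on PANC-1 cells (Homo sapiens) for antiproliferative activity, read by fluorescence and resazurin assay, with a stated time of 48 h (on this read-out lower numbers stand for stronger inhibition and higher numbers for weaker inhibition), compound 1 (`CCOc1ccc2nc(Cl)c(/C=N/NC(=O)c3cc4ccccc4oc3=O)cc2c1`) gives 29900 nM and compound 2 (`Cc1noc(NS(=O)(=O)c2ccc(NC(=O)c3cc4ccccc4oc3=O)cc2)c1C`) gives 19900 nM while compound 3 (`O=C(N/N=C/c1ccncc1)c1cc2cc([N+](=O)[O-])ccc2oc1=O`) gives 26100 nM on the same read-out. These three numbers lie within the usual scatter of one another, so compound 1 stands level with the other two, and no order can be drawn among them even though their structures differ widely.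

Compound 4 (`CCOc1ccc2nc(Cl)c(/C=N/NC(=O)c3cc4cc(Br)ccc4oc3=O)cc2c1`) departs from compound 1 in a single place (bromo in place of hydrogen on an aromatic carbon), with bromo in place of hydrogen on an aromatic carbon. The rest of the structure of compound 1 is kept. Within the data shown here, no two measured compounds differ in only one place, so the data offer no direct measure of what such a change does in this assay and any forecast has to stay cautious. A small step is expected, one that may well stay within the scatter and that leans slightly toward stronger inhibition. The estimate corresponds to an expected 1.5-fold lower number from compound 1 to compound 4 (0.17 log units; within the scatter) and nothing larger. Compound 4 is expected to read 20000 nM and the estimated range runs from 9000 nM to 45000 nM at its two ends.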

Compound 4, half-maximal inhibitory concentration: 17000 nM
Beside the measured number, compound 4's estimate is 1.2-fold (0.07 log units) above it; the measured number falls inside the stated range.
By their numbers in this assay, from the lowest: compounds 4, 2, 3 and 1 (each within the scatter of the next).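

In this assay, among these compounds, the only single-place comparison available puts bromo in place of hydrogen on an aromatic carbon of the six-membered aromatic ring of carbon only, part of a fused or bridged system of two rings, and gives a 1.8-fold lower number from compound 1 to compound 4 (0.25 log units; within the scatter). Among the compounds shown here, this step lies within the usual scatter, so compound 4 stands level with compound 1, and this place on the shared core carries the one added bromine atom with no step beyond the scatter, something the earlier compounds, which differ from one another in more than one place, could not show. No measurement shown bears on why the step has this size.

The compounds shown leave open whether an amine, a carboxylic acid, a methoxy group or fluoro on this same aromatic carbon would also stand level with compound 1 or give a step beyond the scatter. They also leave open whether bromo at this place would give a step of similar size on the rest of the structure of compound 2 or compound 3.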